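The source may report more compounds than this note shows. Statements on the series, on what has been measured and on what is new or still open speak of the compounds shown alone.

Measured so far:
compound 1 `Cc1c(Nc2nc(N)c3c(C#N)c(N4CCC[C@H]4C)n(C)c3n2)cnn1CC(C)(C)O` gives 43 nM in an assay on isolated protein for inhibition of Leucine-rich repeat serine/threonine-protein kinase 2 (Homo sapiens), read by TR-FRET and LanthaScreen, with stated times of 50 min and 30 min, in the presence of a further agent that is not named here; on this read-out lower numbers stand for stronger inhibition and higher numbers for weaker inhibition
compound 2 `CN(C)c1c(C#N)c2c(N)ncnc2n1C` gives 4620 nM in this assay

Compound 2 stands highest of the two numbers. Its nearest neighbour is compound 1, which sits far lower, a gap well beyond the usual scatter. Among the compounds with values here, compound 1 differs from compound 2 in more than one place on the shared core, so the two values show no single change that can be read as a step, and no step between measured compounds is available.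

Compound 3 `Cn1c(N2CCCC2)c(C#N)c2c(N)ncnc21` has not yet been measured in this assay. Against compound 2 the difference is pyrrolidin-1-yl in place of dimethylamino on an aromatic carbon. Compound 1 also carries a five-membered ring on its core, but it differs from compound 2 elsewhere as well, so nothing measured isolates this change. The step from compound 2 to compound 3 is expected to be small, a modest move toward a lower number, with an outcome of no change beyond the scatter also plausible: a 1.8-fold lower number from compound 2 to compound 3 (0.27 log units; within the scatter). Compound 3 is therefore expected near 2500 nM, with a range from 800 nM to 7000 nM.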

Compound 3, half-maximal inhibitory concentration: 1480 nM
Compound 3: the middle estimate sits 1.7-fold (0.23 log units) above what was measured, within the range that was stated.
By their numbers in this assay, from the lowest: compound 1; then compound 3; then compound 2.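

Within this assay the aromatic carbon next to the ring nitrogen now has a change that can be read on its own: pyrrolidin-1-yl in place of dimethylamino gives a 3.1-fold lower number from compound 2 to compound 3 (0.49 log units; beyond the scatter) and this modest step lies beyond the scatter. Compound 1 and compound 2 differ in more than one place, so that pair could not tie any change in the number to this carbon, whereas this pair shows that the amine substituent here affects the number and that a five-membered non-aromatic ring is accepted in place of the open dimethylamino group. No measurement at hand accounts for the step.

The compounds shown do not tell whether the lower number depends on the amine nitrogen being held in a ring or on the added carbon atoms, and piperidin-1-yl, morpholin-4-yl or diethylamino at this carbon would help to separate these readings. Within the data shown here, they also leave open how the same exchange behaves on the core of compound 1, since no pair carrying that core and differing only at this carbon is available.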